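Methoxy for Methyl on an Inactive Triazole Pair

The source may report more compounds than this note shows. Statements on the series, on what has been measured and on what is new or still open speak of the compounds shown alone.

The two measured compounds share a core in which a triazole bears a secondary alcohol linked to a substituted benzene ring. In a functional assay on B16 cells (Mus musculus) for cytotoxicity, read by MTT assay, with a stated time of 48 h (on this read-out lower numbers stand for stronger inhibition and higher numbers for weaker inhibition), compound 1, with structure `COc1ccc(C(O)c2cn(CCCO)nn2)cc1`, gives > 100000 nM, which is a limit of the assay rather than a number. Compound 2, with structure `Cc1ccc(C(O)c2cn(C[C@H]3COC(C)(C)O3)nn2)cc1`, gives in this assay > 100000 nM, again a limit and not a measured number. Compound 2 therefore stands at the edge of what the assay can report, and so does the other value shown: the limit of > 100000 nM in this assay, at which 2 of the 2 values shown sit.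

Compound 3, with structure `COc1ccc(C(O)c2cn(C[C@H]3COC(C)(C)O3)nn2)cc1`, differs from compound 2 by methoxy in place of methyl on an aromatic carbon. This change merely moves the group already present in compound 1 onto the scaffold of compound 2, and both measured compounds sit at the limit. No step beyond the scatter is expected, so compound 3 is estimated at 150000 nM, with a range from 50000 nM to 500000 nM. The expected step that the limit leaves unreadable from compound 2 to compound 3 is essentially none, and the most likely outcome is again a limit.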

Compound 3, half-maximal inhibitory concentration: > 100000 nM
Compound 3 gave a limit, no number; the forecaster's own chance of this, stated with the estimate: 85%; the middle value does not contradict the limit.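

Compound 3 also gives a limit and not a number, so neither its step from compound 2 nor its step from compound 1 can be read: the limit of > 100000 nM in this assay, at which 3 of the 3 values shown sit.

The compounds shown leave open whether methoxy in place of methyl, or the change of chain, makes any difference to cytotoxicity.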